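The compounds below may be only part of what the source reports. "The series", "measured", "known", "first", "only" and "open" are said of these compounds alone.

In a functional assay on A2058 cells (Homo sapiens) for cytotoxicity, read by MTT assay, with a stated time of 24 h (a higher number here means a weaker inhibitor, a lower number a stronger inhibitor), compound 1 `COc1cc(CNC(=O)Nc2ccc([N+](=O)[O-])cc2)ccc1O` gives 98200 nM and compound 2 `COc1cc(CNC(=O)Nc2ccc(Cl)cc2)ccc1O` gives 84500 nM. Among the compounds with values here, these are the only two numbers so far, and compound 2 stands within the scatter of compound 1. The next compound is compound 3 `COc1ccc(NC(=O)NCc2ccc(O)c(OC)c2)cc1`, with this change from compound 2: methoxy in place of chloro on an aromatic carbon. This is methoxy in place of chloro on an aromatic carbon, para to a large group. Within the data shown here, one measured step bears on it, also a swap of one group on an aromatic carbon, chloro in place of nitro: a 1.2-fold lower number from compound 1 to compound 2 (0.07 log units; within the scatter). Among the measured compounds shown here, that step stays within the scatter, and no measured step goes beyond it. No step beyond the scatter is therefore expected in this assay. The expected step is a 1.1-fold higher number from compound 2 to compound 3 (0.03 log units; within the scatter). For compound 3 the estimated value is 90000 nM, with an expected range from 45000 nM to 170000 nM.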

Compound 3, half-maximal inhibitory concentration: 92500 nM
Estimate against measurement, compound 3: 1.0-fold (0.01 log units) below, within the range that was stated.
By their numbers in this assay, from the lowest: compounds 2, 3 and 1 (each within the scatter of the next).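

In this assay, a third group at this aromatic carbon, para to a large group, again gives no step beyond the scatter: methoxy against chloro gives (a 1.1-fold higher number from compound 2 to compound 3 (0.04 log units; within the scatter)) and methoxy against nitro gives (a 1.1-fold lower number from compound 1 to compound 3 (0.03 log units; within the scatter)). Methoxy enters with 2 heavy atoms and 1 hydrogen-bond acceptor, where chloro had 1 heavy atom and 0 acceptors, and this difference comes with no step that can be read as real. Nothing measured here offers an explanation for these small steps.

On these data alone, whether any group at this position can move the number beyond the scatter remains open, for instance an amine, a carboxylic acid or a longer chain. Also open, as far as these compounds go, is whether a change elsewhere on the shared core would do so.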